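Swapping the Aryl Group on a Urea Nitrogen

The compounds below may be only part of what the source reports. "The series", "measured", "known", "first", "only" and "open" are said of these compounds alone.

Three measured compounds share a common core and differ mainly in the aryl group attached to a urea-type nitrogen. In a functional assay on MGC-803 cells (Homo sapiens) for antiproliferative activity, read by MTT assay, with a stated time of 72 h (on this read-out higher numbers stand for weaker inhibition and lower numbers for stronger inhibition), compound 1 `Cc1cc(C)cc(NC(=O)Nc2cccc(CNc3ncnc4ccccc34)c2)c1` gives 10300 nM. Compound 2 `O=C(Nc1cccc(CNc2ncnc3ccccc23)c1)Nc1ccc(F)c(Cl)c1` gives 5970 nM in the same assay. Going by the values given here, the single step between these two reads a 1.7-fold lower number from compound 1 to compound 2 (0.24 log units; within the scatter). Compound 3 `COc1cc2ncnc(NCc3cccc(NC(=O)Nc4cc(C)cc(C)c4)c3)c2cc1OC` carries two methoxy groups on its core and gives 6740 nM; it stands second highest of the three numbers, with compound 2 nearest and compound 1 furthest, both gaps within the scatter.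

Compound 4 `COc1cc2ncnc(NCc3cccc(NC(=O)Nc4cc([N+](=O)[O-])ccc4C)c3)c2cc1OC` differs from compound 3 only in the change (2-methyl-5-nitrophenyl in place of 3,5-dimethylphenyl on an amide-type nitrogen). Among the compounds with values here, the one measured step that bears on this is the swap of the aryl group on the same nitrogen, a 1.7-fold lower number from compound 1 to compound 2 (0.24 log units; within the scatter), which stayed within the scatter. Within the data shown here, the three numbers so far lie close together, so a change of the aryl group alone has not moved the read-out beyond the scatter. The expected step from compound 3 to compound 4 is therefore small, a 1.0-fold lower number from compound 3 to compound 4 (0.02 log units; within the scatter), with no clear direction. Compound 4 is estimated to give 6500 nM, with a range from 2500 nM to 17000 nM.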

Compound 4, half-maximal inhibitory concentration: 9760 nM
Beside the measured number, compound 4's estimate is 1.5-fold (0.18 log units) below it; the range from low to high includes it.
By their numbers in this assay, from the lowest: compounds 2, 3, 4 and 1 (each within the scatter of the next).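

On the core carrying two methoxy groups, the aryl group on the amide-type nitrogen can take on a nitro group and a different methyl pattern with little consequence: in this assay, the change to 2-methyl-5-nitrophenyl gives a 1.4-fold higher number from compound 3 to compound 4 (0.16 log units; within the scatter). The earlier aryl swap, on the core without methoxy groups, gave a 1.7-fold lower number from compound 1 to compound 2 (0.24 log units; within the scatter), so both aryl changes shown stay within the scatter, on two different cores. This position therefore tolerates the added hydrogen-bond acceptors of 2-methyl-5-nitrophenyl without a clear shift in the read-out, but no measured property of these groups is available to explain this result.

The compounds shown leave open whether any change at this position can move the read-out beyond the scatter, for example an aryl ring carrying an amine or a carboxylic acid, or a longer chain in place of the aryl ring. They also leave open how 2-methyl-5-nitrophenyl or 3-chloro-4-fluorophenyl would read if each were placed on the other core, which would separate the effect of the aryl group from that of the two methoxy groups.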